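A few compounds are considered here, and "the series" means these few. Any claim that something is new, unique, unknown or untested is made for them only; others in the source may bear on it.

Values in a functional assay on MV4-11 cells (Homo sapiens) for antiproliferative activity, read by CCK-8 assay, with a stated time of 72 h; a higher number here means a weaker inhibitor, a lower number a stronger inhibitor:
compound 1 (`CC(C)Oc1ccccc1-c1cn(C)c(=O)c2[nH]c(C(=O)NCc3ccc(C(=O)Nc4ccccc4N)cc3)cc12`): 130 nM
compound 2 (`Cn1cc(-c2ccccc2)c2cc(C(=O)NCc3ccc(C(=O)Nc4ccccc4N)cc3)[nH]c2c1=O`): 230 nM
compound 3 (`Cn1cc(-c2ccc(F)cc2)c2cc(C(=O)NCc3ccc(C(=O)Nc4ccccc4N)cc3)[nH]c2c1=O`): 220 nM

Compound 3 (220 nM) cannot be told apart from compound 1 and compound 2, since every step among the three lies within the scatter. Compound 4 (`COc1ccc(-c2cn(C)c(=O)c3[nH]c(C(=O)NCc4ccc(C(=O)Nc5ccccc5N)cc4)cc23)cc1`) carries methoxy in place of fluoro on an aromatic carbon, para to a large group. The nearest measured change is fluoro in place of hydrogen on that carbon, a 1.0-fold lower number from compound 2 to compound 3 (0.02 log units; within the scatter). The other two steps, both changing the same aromatic ring, are a 1.8-fold higher number from compound 1 to compound 2 (0.25 log units; within the scatter) and a 1.7-fold higher number from compound 1 to compound 3 (0.23 log units; within the scatter). Among the compounds with values here, none of the three moves the number beyond the scatter, and no compound measured so far carries methoxy on this carbon, so the precedent is indirect. No shift beyond the scatter is therefore expected, and the estimated step is a 1.1-fold lower number from compound 3 to compound 4 (0.04 log units; within the scatter). Compound 4 is estimated at 200 nM (expected range 100 nM to 400 nM).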

Compound 4, half-maximal inhibitory concentration: 320 nM
Estimate against measurement, compound 4: 1.6-fold (0.20 log units) below; the measured number falls inside the stated range.
By their numbers in this assay, from the lowest: compounds 1, 3, 2 and 4 (each within the scatter of the next, the first and the last beyond it).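

On the aromatic carbon para to a large group, methoxy stays within the scatter of both fluoro (a 1.5-fold higher number from compound 3 to compound 4 (0.16 log units; within the scatter)) and hydrogen (a 1.4-fold higher number from compound 2 to compound 4 (0.14 log units; within the scatter)), so in this assay none of these three groups separates from the others at this position. The only step beyond the scatter among the compounds shown is modest (a 2.5-fold higher number from compound 1 to compound 4 (0.39 log units; beyond the scatter)); there 4-methoxyphenyl replaces 2-isopropoxyphenyl, so the group and its place on the ring change together and the step cannot be assigned to either alone. Nothing available here explains these results.

On these data alone, it remains open whether 4-isopropoxyphenyl or 2-methoxyphenyl would separate the effect of the group from that of its place on the ring. As far as these compounds go, it is also open whether an amine or a carboxylic acid on this carbon would move the number beyond the scatter.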